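Aryl ketone in place of isobutyl ketone at the ketone carbonyl

The source may report more compounds than this note shows. Statements on the series, on what has been measured and on what is new or still open speak of the compounds shown alone.

Among the measured compounds shown here, compound 3 `CCOC(=O)N1CCN(CCCOc2ccc(C(=O)CC(C)C)cc2)CC1` gives 69200 nM in an assay on isolated protein for binding affinity to histamine H2 receptor (Homo sapiens) (on this read-out higher numbers stand for weaker inhibition and lower numbers for stronger inhibition), the highest of the three numbers measured so far. Compound 2 `CCCCCC(=O)c1ccc(OCCCN2CCN(C(=O)C(C)C)CC2)cc1` gives 29500 nM and compound 1 `CCCCCC(=O)c1ccc(OCCCN2CCN(C(=O)OCC(C)C)CC2)cc1` gives 3720 nM; both sit below compound 3, compound 1 furthest. For the measured compounds named here, the single one-point step measured, a 7.9-fold higher number from compound 1 to compound 2 (0.90 log units; beyond the scatter), concerns the carbamate carbonyl, not the ketone. Compound 4 `CCOC(=O)N1CCN(CCCOc2ccc(C(=O)c3ccc(C(C)(C)C)cc3)cc2)CC1` differs from compound 3 by 4-(tert-butyl)phenyl in place of isobutyl on a carbonyl carbon. Going by the values given here, no measured step touches the ketone carbonyl, so the expectation rests on the change alone and is uncertain. A modestly lower number is expected for compound 4, a step of a 3.5-fold lower number from compound 3 to compound 4 (0.54 log units; beyond the scatter). The estimate for compound 4 is 20000 nM, with a range from 4000 nM to 100000 nM.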

Compound 4, inhibition constant: 1550 nM
Beside the measured number, compound 4's estimate is 13-fold (1.11 log units) above it, outside the stated range (below it).
By their numbers in this assay, from the lowest: compound 4; then compound 1; then compound 2; then compound 3.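

At the ketone carbonyl, which the earlier step left untouched, a 45-fold lower number from compound 3 to compound 4 (1.65 log units; beyond the scatter) in this assay shows that this position responds strongly to the group on the carbonyl carbon. The change adds one six-membered aromatic ring and brings in the tert-butyl group, and no hydrogen-bond donors or acceptors enter with it. Nothing available here explains the size of this step.

Going by these compounds, whether the ring or its tert-butyl group carries the step remains open. An unsubstituted phenyl or a 4-carboxyphenyl on the same carbonyl would help separate the two.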